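The compounds below may be only part of what the source reports. "The series", "measured", "known", "first", "only" and "open" are said of these compounds alone.

Compound 1 `CN(C)CCNC(=O)c1ccccc1Sc1ccccc1` and compound 2 `CN(C)CCNCc1ccccc1Sc1ccccc1` share a core and were both tested in an assay for inhibition of protein arginine N-methyltransferase 1 (Rattus norvegicus), read by scintillation counting, with stated times of 15 min and 60 min, in the presence of a further agent that is not named here; on this read-out higher numbers stand for weaker inhibition and lower numbers for stronger inhibition. For compound 1 the read-out in this assay is a limit of the assay, > 50000 nM. For compound 2 the read-out in this assay is likewise a limit, > 50000 nM. Where compound 2 stands is therefore (the limit of > 50000 nM in this assay, at which 2 of the 2 values shown sit), with no number behind it.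

The unmeasured compound 3 `CN(C)CCNCc1ccccc1Sc1ccccc1F` differs from compound 2 by fluoro in place of hydrogen on an aromatic carbon, in words fluoro in place of hydrogen on an aromatic carbon. Among the measured compounds shown here, no step between measured compounds is available to gauge the size of such a change here. The expected step in this assay is a number no higher from compound 2 to compound 3 (the limit leaves the size open), none beyond the scatter, and the read-out for compound 3 is expected most likely to be another limit. Compound 3 is estimated at 50000 nM, between 20000 nM and 150000 nM.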

Compound 3, half-maximal inhibitory concentration: 45000 nM
Compound 3: middle estimate off by 1.1-fold (0.05 log units), on the high side, and the stated range covers the measured number.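

In this assay compound 3 gives 45000 nM, the first read-out in the series that is a number and not a limit of the assay. It shows that fluoro on an aromatic carbon, ortho to a large group, is tolerated at this position and gives an at least 1.1-fold lower number from compound 2 to compound 3 (0.04 log units; that floor lies within the scatter). How large the step really is cannot be told, because compound 2 offers only a limit as its starting point: the limit of > 50000 nM in this assay, at which 2 of the 3 values shown sit.

On these data alone, whether chloro, methyl or methoxy in the same place would give a clearly lower number stays open, and one fluoro alone cannot show a trend. Among the compounds shown here, also open is whether a longer chain in place of the one carrying the dimethylamino group would change the read-out in this assay.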